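The compounds below may be only part of what the source reports. "The series", "measured", "known", "first", "only" and "open" are said of these compounds alone.

In a functional assay on HCT-116 cells (Homo sapiens) for inhibition (a lower number here means a stronger inhibitor, a higher number a weaker inhibitor), three compounds on the shared core have been examined, and they differ in one side chain. Compound 1 (`CCNC(=O)c1noc(-c2cc(C(C)C)c(O)cc2O)c1-c1cc(COCC(=O)O)no1`) has the entry "not determined" (no result reported) and offers no number to work from. Compound 3 (`CCNC(=O)c1noc(-c2cc(C(C)C)c(O)cc2O)c1-c1cc(CNC(C)C)no1`) reads 109 nM as the reference point, within the scatter of compound 2 (`CCNC(=O)c1noc(-c2cc(C(C)C)c(O)cc2O)c1-c1cc(CNC)no1`) at 164 nM on the same read-out. Among the measured compounds shown here, the only measured step is a 1.5-fold lower number from compound 2 to compound 3 (0.18 log units; within the scatter) for isopropyl in place of methyl on an amine nitrogen.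

Compound 4 (`CCNC(=O)c1noc(-c2cc(C(C)C)c(O)cc2O)c1-c1cc(CNC(C)=O)no1`) carries acetyl in place of isopropyl on an amine nitrogen and so has an acetamidomethyl group where compound 3 has an (isopropylamino)methyl group. For the measured compounds named here, the measured step offers only limited guidance here, since it exchanged one alkyl group for another and no measured compound carries an acetamido group. Starting from compound 3 at 109 nM as the anchor, a modest move towards a higher number in this assay is expected, with a wide margin on it. The estimated step is a 2.2-fold higher number from compound 3 to compound 4 (0.34 log units; beyond the scatter) in the direction of weaker inhibition. For compound 4 the estimated value is 240 nM with an expected range from 80 nM to 750 nM for repeat measurements.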

Compound 4, half-maximal inhibitory concentration: 167 nM
Estimate against measurement, compound 4: 1.4-fold (0.16 log units) above, and the stated range covers the measured number.
By their numbers in this assay, from the lowest: compounds 3, 2 and 4 (each within the scatter of the next).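

In this assay, putting acetyl on the amine nitrogen gives a 1.5-fold higher number from compound 3 to compound 4 (0.19 log units; within the scatter), and the comparison with the methyl-bearing amine gives a 1.0-fold higher number from compound 2 to compound 4 (0.01 log units; within the scatter). Among the compounds shown here, the earlier pair showed only one alkyl group exchanged for another, whereas this change brings in a carbonyl and turns the isopropylamino group into an acetamido group, and the number still stays within the scatter of both amines. Across compound 2, compound 3 and compound 4, the side chain at this position therefore tolerates both alkylamino and acetamido forms in this cell read-out, and no available evidence bears on why these numbers stay so close.

The compounds shown leave open whether any change on this amine nitrogen can separate the numbers beyond the scatter, for example a methanesulfonyl group, a longer acyl chain or a benzoyl group. They also leave open whether a tertiary amine or a cyclic amine such as piperidine or morpholine, in place of the secondary amine and the acetamido group, would read any differently from compound 3.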